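A few compounds are considered here, and "the series" means these few. Any claim that something is new, unique, unknown or untested is made for them only; others in the source may bear on it.

Compound 1 `CC(=O)Nc1cccc(-n2c(Nc3ccc(F)cc3)nc3cnc(Nc4ccc(N5CCN(C)CC5)cc4)nc32)c1` gives 10 nM in a functional assay on HCC827 cells (Homo sapiens) for antiproliferative activity, read by MTT assay, with a stated time of 72 h; a higher number here means a weaker inhibitor, a lower number a stronger inhibitor. Within the data shown here, compound 2 `CN1CCN(c2ccc(Nc3ncc4nc(Nc5ccc(F)cc5)n([C@H]5CCN(C(=O)OC(C)(C)C)C5)c4n3)cc2)CC1` stands highest of the two numbers, with 580 nM in this assay; the one recorded step, a 58-fold higher number from compound 1 to compound 2 (1.76 log units; beyond the scatter), separates them. Compound 3 `CN1CCN(c2ccc(Nc3ncc4nc(Nc5ccc(F)cc5)n([C@H]5CCN(S(=O)(=O)C6CC6)C5)c4n3)cc2)CC1` carries cyclopropylsulfonyl in place of tert-butoxycarbonyl on an amine nitrogen in a ring. Among the measured compounds shown here, no measured step bears on this exchange, as the single step concerns another part of the molecule, so nothing in the data points to a change in this assay beyond the scatter in either direction. Compound 3 is therefore estimated at 500 nM, within 150 nM to 1700 nM. The expected step is a 1.2-fold lower number from compound 2 to compound 3 (0.06 log units; within the scatter).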

Compound 3, half-maximal inhibitory concentration: 7.5 nM
The estimate for compound 3 lay 67-fold (1.82 log units) above the measured number, outside the stated range (below it).
By their numbers in this assay, from the lowest: compounds 3 and 1 (each within the scatter of the next); then compound 2.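

In this assay the group on the amine nitrogen of the five-membered ring decides the outcome, as cyclopropylsulfonyl in place of tert-butoxycarbonyl gives a 77-fold lower number from compound 2 to compound 3 (1.89 log units; beyond the scatter) on an otherwise unchanged molecule. The earlier loss thus did not follow from the pyrrolidine itself, since 1-(cyclopropylsulfonyl)pyrrolidin-3-yl in place of 3-acetamidophenyl gives a 1.3-fold lower number from compound 1 to compound 3 (0.12 log units; within the scatter) and leaves the two compounds level. Nothing available explains this difference. On these data alone, it remains open whether the sulfonyl or the cyclopropyl ring matters more, and whether methylsulfonyl, an acetyl group or the free amine on that nitrogen would behave alike.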